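Phenoxy halogen and position change in an antiproliferative series

The source may report more compounds than this note shows. Statements on the series, on what has been measured and on what is new or still open speak of the compounds shown alone.

Measured compounds in a functional assay on U-87MG ATCC cells for antiproliferative activity against U-87 MG (Homo sapiens), read by MTT assay, with a stated time of 72 h; a higher number here means a weaker inhibitor, a lower number a stronger inhibitor:
Compound 1, `Cc1nn(C)c(Oc2ccc(F)cc2)c1/C=N\CCCCCOc1cc2oc(=O)cc(C)c2cc1Cl`, gives > 25000 nM, a limit of the assay and not a number.
Compound 2, `Cc1nn(C)c(Oc2ccc(Br)cc2)c1/C=N\CCCCCOc1cc2oc(=O)cc(C)c2cc1Cl`, gives 15300 nM.
Compound 3, `Cc1nn(C)c(Oc2ccc(F)cc2)c1/C=N\CCCCCCOc1cc2oc(=O)cc(C)c2cc1Cl`, gives 16700 nM.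

Compound 3 and compound 2 give numbers that lie within the scatter of each other; compound 1 contributes only a limit, see (the limit of > 25000 nM in this assay, at which 1 of the 3 values shown sits). Compound 4, `Cc1nn(C)c(Oc2cccc(Br)c2)c1/C=N\CCCCCCOc1cc2oc(=O)cc(C)c2cc1Cl`, is not yet measured. It differs from compound 3 by 3-bromophenyl in place of 4-fluorophenyl on an oxygen on an aromatic ring. Going by the values given here, the one measured step that bears on this is an at least 1.6-fold lower number from compound 1 to compound 2 (0.21 log units; that floor lies within the scatter), which covers the bromo for fluoro part of the change but not the shift of the halogen to the 3-position of the phenyl; the shift itself has no measured counterpart here. A step of similar small size, toward a lower number, or none beyond the scatter, is therefore expected for compound 4 in this assay, as a 1.4-fold lower number from compound 3 to compound 4 (0.14 log units; within the scatter). Compound 4 is estimated at 12000 nM, with a range from 5000 nM to 30000 nM.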

Compound 4, half-maximal inhibitory concentration: 3610 nM
Compound 4: the middle estimate sits 3.3-fold (0.52 log units) above what was measured; the whole stated range lies above it.
By their numbers in this assay, from the lowest: compound 4; then compounds 2 and 3 (each within the scatter of the next). At a limit, above all of these: compound 1.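

In this assay, going by these compounds alone, the phenyl on the oxygen is the first place where a change moves the number beyond the scatter, giving a 4.6-fold lower number from compound 3 to compound 4 (0.67 log units; beyond the scatter) with 3-bromophenyl in place of 4-fluorophenyl. The earlier step at this group, an at least 1.6-fold lower number from compound 1 to compound 2 (0.21 log units; that floor lies within the scatter), exchanged the halogen alone, whereas this change also moves it to the 3-position of the phenyl. The position therefore responds to halogen identity and placement taken together, though this rests on a single pair on one chain.

Whether the bromo or the shift carries the step stays open, since 3-fluorophenyl and 4-bromophenyl on the chain of compound 3 lie outside the compounds shown, as does a phenyl bearing an amine or a carboxylic acid. Nothing shown gives a reason for the step.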